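Aryl variation in the vinyl sulfide chalcone series

The source may report more compounds than this note shows. Statements on the series, on what has been measured and on what is new or still open speak of the compounds shown alone.

Measured so far:
compound 1 `Cc1ccsc1/C=C(/SCc1ccc(Cl)c(Cl)c1)C(=O)c1ccc(Cl)cc1`, 50000 nM
compound 2 `COc1ccccc1/C=C(/SCc1ccc(C)cc1)C(=O)c1ccc(Cl)cc1`, 10000 nM
compound 3 `COc1ccc(OC)c(/C=C(/SCc2ccc(Cl)c(Cl)c2)C(=O)c2ccc(Cl)cc2)c1`, 10000 nM

In a functional assay on DU-145 cells (Homo sapiens) for inhibition, read by trypan blue exclusion, with a stated time of 96 h (a higher number here means a weaker inhibitor of growth, a lower number a stronger inhibitor of growth), compound 3 gives 10000 nM and stands level with compound 2 at the digits shown, the two together being the lowest of the three numbers; compound 1 sits furthest off, the step of a 5.0-fold lower number from compound 1 to compound 3 (0.70 log units; beyond the scatter) being the only one-place change measured. Compound 4 `COc1ccccc1/C=C(/SCc1ccc(Cl)c(Cl)c1)C(=O)c1ccc(Cl)cc1` differs from compound 3 by hydrogen in place of methoxy on an aromatic carbon. Going by the values given here, no measured step isolates this change; compound 2 also carries the 2-methoxyphenyl group, yet with a different benzyl thioether, and its value matches compound 3. On that basis the expected step of no change at the digits printed from compound 3 to compound 4 (within the scatter) is none beyond the scatter, and compound 4 is estimated at 10000 nM, with a range from 5000 nM to 30000 nM.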

Compound 4, concentration for 50% growth inhibition: 10000 nM
The estimate for compound 4 equals the measured number at the digits printed; low and high end bracket the measured number.
By their numbers in this assay, from the lowest: compounds 2, 3 and 4 (each within the scatter of the next); then compound 1.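

In this assay hydrogen in place of methoxy gives no change at the digits printed from compound 3 to compound 4 (within the scatter), so this position on the ring, para to a methoxy group, shows no dependence on methoxy. The benzyl thioether is now isolated, with 3,4-dichlorophenyl in place of 4-methylphenyl giving no change at the digits printed from compound 2 to compound 4 (within the scatter) as the only difference. The aryl change alone, 2-methoxyphenyl in place of 3-methylthiophen-2-yl, gives a 5.0-fold lower number from compound 1 to compound 4 (0.70 log units; beyond the scatter) and so keeps the gap to compound 1 without the second methoxy.

On these data alone, an amine or a carboxylic acid at this position remains open. No evidence here bears on why these steps take the sizes they do.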